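Replacing an Amide Arm with Methoxy: Expected Cell Tolerance

The compounds below may be only part of what the source reports. "The series", "measured", "known", "first", "only" and "open" are said of these compounds alone.

Of the compounds shown here, three have so far been tested in an ADME assay on Vero cells (Chlorocebus sabaeus) for cytotoxicity; a higher number here means that more compound is tolerated, a lower number that less compound is tolerated. Compound 1 `O=C(CN1CCCCC1)Nc1ccc(-c2nc3ccccc3[nH]2)cc1` reaches only the limit of the assay, > 100000 nM. Compound 3 `CN1CCN(CC(=O)Nc2ccc(-c3nc4cc(Cl)c(Cl)cc4[nH]3)cc2)CC1` likewise gives a limit, > 100000 nM. Among the compounds with values here, compound 2 `O=C(CCl)Nc1ccc(-c2nc3cc(C(F)(F)F)ccc3[nH]2)cc1` is the single compound with a measured number, 35000 nM, and so it stands below (the limit of > 100000 nM in this assay, at which 2 of the 3 values shown sit). Within the data shown here, no pair of measured compounds differs in only one place, so the size of any single structural change in this assay is still unknown.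

Compound 4 `COc1ccc(-c2nc3cc(C(F)(F)F)ccc3[nH]2)cc1` has not yet been tested. It differs from compound 2 in one place: methoxy in place of ((chloromethyl)carbonyl)amino on an aromatic carbon. Compound 2 gives 35000 nM. The two other compounds each sit at a limit of the assay. Because compound 2 stands below (the limit of > 100000 nM in this assay, at which 2 of the 3 values shown sit), the expectation is that taking away the ((chloromethyl)carbonyl)amino group lets more compound be tolerated. The step is expected to be a 2.3-fold higher number from compound 2 to compound 4 (0.36 log units; beyond the scatter), beyond the usual scatter. Compound 4 is accordingly estimated at 80000 nM, with a range from 30000 nM to 200000 nM and a fair chance that only a limit is reported.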

Compound 4, half-maximal cytotoxic concentration: 15000 nM
Beside the measured number, compound 4's estimate is 5.3-fold (0.73 log units) above it; the whole stated range lies above it.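

At this position, on an aromatic carbon para to a large group, methoxy in place of ((chloromethyl)carbonyl)amino gives a 2.3-fold lower number from compound 2 to compound 4 (0.37 log units; beyond the scatter) in this assay. Within the data shown here, this is the first single change that can be read in this assay, and it runs toward less compound tolerated, so taking away the ((chloromethyl)carbonyl)amino group does not by itself lift tolerance here. Neither compound 2 nor compound 4 reaches the limit of the assay: the limit of > 100000 nM in this assay, at which 2 of the 4 values shown sit.

Still open is whether the step comes from losing the ((chloromethyl)carbonyl)amino group or from adding methoxy, as only this one replacement at this position is shown. A plain amine or a hydroxyl group at the same place could help separate those two readings, and a piperidine-bearing arm like that of compound 1 on this same core could show how much the arm matters.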